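A few compounds are considered here, and "the series" means these few. Any claim that something is new, unique, unknown or untested is made for them only; others in the source may bear on it.

Compound 3, `O=S(=O)(Nc1cccc2cccnc12)c1cccs1`, gives 250% in an assay on OCI-Ly3 cells for activation of NF-kappa-B inhibitor alpha (Homo sapiens), read by a luciferase reporter (a lower number here means a smaller maximal response, a higher number a larger maximal response), the highest of the three values recorded there. Compound 1, `O=[N+]([O-])c1cc(C(F)(F)F)ccc1S(=O)(=O)Nc1cccc2cccnc12`, gives 200%, and compound 2, `Cc1ccc2cccc(NS(=O)(=O)c3ccc(C(F)(F)F)cc3[N+](=O)[O-])c2n1`, gives 50%; compound 3 thus stands above compound 1 by a margin beyond the scatter and further still above compound 2. Compound 4, `O=S(=O)(Nc1cccc2cccnc12)c1ccc(Cl)s1`, differs from compound 3 by chloro in place of hydrogen on an aromatic carbon. Among the compounds with values here, the only measured step between neighbours that differ in one place is a number 150 percentage points lower from compound 1 to compound 2 (beyond the scatter), a methyl entering on an aromatic carbon of the shared core, not on the five-membered ring that carries the chloro in compound 4. It shows that a small group can shift this assay strongly, but at another place and on another part of the molecule, so it gives no direction for the present change. Within the data shown here, no measured step touches the five-membered ring with one sulfur at all. Compound 4 is therefore expected to remain close to its parent, with a step of no change at the digits printed from compound 3 to compound 4 (within the scatter), none beyond the scatter, though the range is kept wide because a number 150 percentage points lower from compound 1 to compound 2 (beyond the scatter) shows how large a single substituent's effect can be. The estimate for compound 4 is 250%, within a range from 150% to 350%.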

Compound 4, largest response reached (reported as efficacy), in percent of the reference or control that the assay uses: 190%
Compound 4: middle estimate off by 60 percentage points, on the high side, and the stated range covers the measured number.
By their numbers in this assay, from the lowest: compound 2; then compounds 4 and 1 (each within the scatter of the next); then compound 3.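

Chloro in place of hydrogen gives a number 60 percentage points lower from compound 3 to compound 4 (beyond the scatter) in this assay, the first measured step on the five-membered aromatic ring with 1 sulfur. It shows that this place, next to the ring sulfur and two ring bonds from the ring atom that bears a large group, is not silent: one added chlorine moves the maximal response beyond the scatter, so the response depends on this ring as well as on the shared core, where the methyl step gave a number 150 percentage points lower from compound 1 to compound 2 (beyond the scatter). No measurement is available that bears on why chloro lowers the response at this place.

The compounds shown hold only hydrogen and chloro at this place, so it remains open whether a bromo, a methoxy group or an amine there would lower the response as far, lower it less or raise it. Also open, on these data alone, is whether chloro on the other carbons of the five-membered ring would give a step of the same direction and size, and whether the step would carry over to a parent that bears the methyl on the shared core.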